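A Phenyl for a Methyl on an Inactive Core

The source may hold more compounds than are shown below. What is called first, only, known or untested is meant among the compounds shown, and "the series" means these compounds.

Compound 1 `Cc1oc2c3c(ccc2c(=O)c1C)OC[C@H]1[C@@H]3C2=C(CCCC2=O)OC1(C)C` was tested in an ADME assay on MRC5 cells (Homo sapiens) for antiproliferative activity, read by MTT assay, with a stated time of 48 h; a higher number here means a weaker inhibitor, a lower number a stronger inhibitor. In this assay compound 1 gives > 100000 nM, which is a limit of the assay rather than a measured number. Its close neighbour, compound 2 `Cc1coc2c3c(ccc2c1=O)OC[C@H]1[C@@H]3C2=C(CCCC2=O)OC1(C)C`, carries a hydrogen in place of methyl on an aromatic carbon. In this assay compound 2 gives > 100000 nM, again a limit. The change between these two is a step that the two limits leave unreadable from compound 1 to compound 2. Compound 1 thus stands where every value shown stands: the limit of > 100000 nM in this assay, at which 2 of the 2 values shown sit.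

Compound 3 `Cc1oc2c3c(ccc2c(=O)c1-c1ccccc1)OC[C@H]1[C@@H]3C2=C(CCCC2=O)OC1(C)C` has not yet been measured. It differs from compound 1 by phenyl in place of methyl on an aromatic carbon. The only step shown, a step that the two limits leave unreadable from compound 1 to compound 2, touches the same aromatic carbon, yet its size cannot be read, so no direction and no size beyond the scatter can be drawn from it for the change to phenyl. Compound 3 is therefore expected to give 150000 nM in this assay, with an estimated range from 30000 nM to 600000 nM, most probably reported again only as a limit. The step from compound 1 to compound 3 that this estimate means is a step that the limit leaves unreadable from compound 1 to compound 3, an expectation and not a measurement.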

Compound 3, half-maximal inhibitory concentration: > 100000 nM
Compound 3: no number, only a limit; the forecaster's own chance of this, stated with the estimate: 80%; the middle value lies beyond the limit too.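

Compound 3 gives > 100000 nM in this assay, again a limit and not a number, so no step from compound 1 to compound 3 can be read: the limit of > 100000 nM in this assay, at which 3 of the 3 values shown sit.

The compounds shown leave open whether methyl, hydrogen and phenyl on this aromatic carbon differ at all, and whether any compound with the shared core gives a readable value in this assay.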